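Phenyl for furan-2-yl on compound 3

The source may report more compounds than this note shows. Statements on the series, on what has been measured and on what is new or still open speak of the compounds shown alone.

Compound 1 `Nc1nc(N)c2c(-c3ccco3)cn([C@@H]3O[C@H](CO)[C@@H](O)[C@H]3O)c2n1`: > 20000 nM
Compound 2 `Cc1nc(N)c2c(-c3cc4ccccc4o3)cn([C@@H]3O[C@H](CO)[C@@H](O)[C@H]3O)c2n1`: > 20000 nM
Compound 3 `COc1nc(N)nc2c1c(-c1ccco1)cn2[C@@H]1O[C@H](CO)[C@@H](O)[C@H]1O`: > 20000 nM

All three entries come from a functional assay on HepG2 cells (Homo sapiens) for antiproliferative activity, read by XTT assay, with a stated time of 72 h (on this read-out lower numbers stand for stronger inhibition and higher numbers for weaker inhibition), and all three are limits of the assay, not numbers. Compound 3 gives > 20000 nM, which is such a limit. It therefore shares one spot with the other two compounds, (the limit of > 20000 nM in this assay, at which 3 of the 3 values shown sit), and no order among the three can be read.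

The next compound, compound 4 `COc1nc(N)nc2c1c(-c1ccccc1)cn2[C@@H]1O[C@H](CO)[C@@H](O)[C@H]1O`, keeps the core and the methoxy group of compound 3 and changes one group: phenyl in place of furan-2-yl on an aromatic carbon. This change is phenyl in place of furan-2-yl on an aromatic carbon.

Going by the values given here, only one measured step exists, a step that the two limits leave unreadable from compound 1 to compound 3. It concerns a different change, methoxy in place of amino on an aromatic carbon, and its size cannot be read, so it offers no size to carry over. Among the compounds with values here, no measured step swaps phenyl for furan-2-yl.

Within the data shown here, with every value so far at the limit, the expectation is no readable change in this assay and no direction to name, and another limit is the likeliest report. For compound 4 the estimated value is 20000 nM, with an expected range from 8000 nM to 40000 nM. The estimate means an expected a number no higher from compound 3 to compound 4 (the limit leaves the size open).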

Compound 4, half-maximal inhibitory concentration: > 20000 nM
Compound 4 ended at the assay's limit (the forecaster's own chance of this, stated with the estimate: 85%); the middle value sits exactly at the limit.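

In this assay compound 4 gives > 20000 nM, which is a limit of the assay and not a number. Compound 3 is also at a limit, so no size can be read for the change between compound 3 and compound 4: the limit of > 20000 nM in this assay, at which 4 of the 4 values shown sit.

The compounds shown leave open whether phenyl or furan-2-yl gives stronger inhibition, since none of the four has an actual number.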